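Shifting the halogens on the aniline of compound 3

The compounds below may be only part of what the source reports. "The series", "measured", "known", "first", "only" and "open" are said of these compounds alone.

Compound 3 `COc1cc2ncnc(Nc3ccc(F)c(Br)c3)c2cc1OCCCCC(=O)Nc1ccc(S(N)(=O)=O)cc1` is tested in a functional assay on A549 cells (Homo sapiens) for antiproliferative activity, read by MTT assay, with a stated time of 72 h (a lower number here means a stronger inhibitor, a higher number a weaker inhibitor), where it gives 16000 nM. Among the two plain numbers it holds the highest value, and its nearest neighbour is compound 1 `COc1cc2ncnc(Nc3ccc(F)c(Cl)c3)c2cc1OCCCCC(=O)Nc1ccc(S(N)(=O)=O)cc1`, which in this assay gives 15500 nM; the step of a 1.0-fold higher number from compound 1 to compound 3 (0.01 log units; within the scatter) is small. Compound 2 `COc1ccc(Nc2ncnc3cc(OC)c(OCCCCC(=O)Nc4ccc(S(N)(=O)=O)cc4)cc23)cc1` is a different case: in this assay its result is only a limit, > 40000 nM, and the step of an at least 2.5-fold lower number from compound 2 to compound 3 (0.39 log units; beyond the scatter) is at least modest. Compound 4 `COc1cc2ncnc(Nc3cccc(Cl)c3F)c2cc1OCCCCC(=O)Nc1ccc(S(N)(=O)=O)cc1` is not yet measured. It differs from compound 3 in one place: 3-chloro-2-fluorophenyl in place of 3-bromo-4-fluorophenyl on a nitrogen on an aromatic ring. Among the measured compounds shown here, no measured step repeats this exact exchange. The step of a 1.0-fold higher number from compound 1 to compound 3 (0.01 log units; within the scatter) shows that swapping one halogen for another within the same pattern hardly moves the number, while the step of an at least 2.5-fold higher number from compound 1 to compound 2 (0.41 log units; beyond the scatter) shows that removing the halogens for a methoxy group weakens the compound by at least a modest amount. The change to compound 4 keeps both halogens but rearranges them, so the expectation is a step of a 1.3-fold higher number from compound 3 to compound 4 (0.10 log units; within the scatter) in this assay, within or close to the scatter. Compound 4 is therefore estimated at 20000 nM, with a range from 8000 nM to 45000 nM.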

Compound 4, half-maximal inhibitory concentration: 10500 nM
Beside the measured number, compound 4's estimate is 1.9-fold (0.28 log units) above it, and the stated range covers the measured number.
By their numbers in this assay, from the lowest: compounds 4, 1 and 3 (each within the scatter of the next). At a limit, above all of these: compound 2.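

Rearranging the halogens to give the 3-chloro-2-fluorophenyl group leaves the result within the scatter of both halogen-bearing neighbours in this assay, as the steps of a 1.5-fold lower number from compound 3 to compound 4 (0.18 log units; within the scatter) and a 1.5-fold lower number from compound 1 to compound 4 (0.17 log units; within the scatter) show, so the tolerance seen earlier for swapping one halogen for another now also covers a different halogen pattern, though only across these three compounds. Compound 4 also stands clearly apart from the 4-methoxyphenyl compound, with the step of an at least 3.8-fold lower number from compound 2 to compound 4 (0.58 log units; beyond the scatter), which extends to a third halogen-bearing compound the gap already seen for compound 1 and compound 3. That step rests on a limit, not a plain number, and the limit belongs to compound 2: the limit of > 40000 nM in this assay, at which 1 of the 4 values shown sits.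

From the compounds shown here alone, what remains open is how far this tolerance reaches on the aniline ring, for instance whether a plain phenyl, a ring bearing a single fluoro group or one bearing a trifluoromethyl group would stay in the same range. The chain is also the same in all four compounds, so the effect of a shorter chain, a longer chain or a carboxylic acid at its end cannot be judged from them.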